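Amide series: piperidin-1-yl in place of ethyl

The source may report more compounds than this note shows. Statements on the series, on what has been measured and on what is new or still open speak of the compounds shown alone.

Compound 1 `C=CCOc1ccc(C(=O)Nc2cccc(C)n2)cc1` gives 6000 nM in an in vitro assay on HEK-tsA201 cells for antagonist activity at Neuronal acetylcholine receptor; alpha4/beta2 (Homo sapiens), read by fluorescence and calcium flux; on this read-out higher numbers stand for weaker inhibition and lower numbers for stronger inhibition. Compound 2 `CCCOc1ccc(C(=O)Nc2cccc(CC)n2)cc1` gives 37600 nM in this assay, the higher of the two numbers, with a gap to compound 1 that lies beyond the scatter. Compound 3 `CCCOc1ccc(C(=O)Nc2cccc(N3CCCCC3)n2)cc1` differs from compound 2 by piperidin-1-yl in place of ethyl on an aromatic carbon, a larger group entering on an aromatic carbon of the six-membered aromatic ring with 1 nitrogen. Within the data shown here, no measured pair shows this change, so the direction is open; the expected step of a 1.5-fold lower number from compound 2 to compound 3 (0.18 log units; within the scatter) is small, within the scatter, with wide uncertainty. Compound 3 is therefore estimated at 25000 nM, in the range 5000 nM to 100000 nM.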

Compound 3, half-maximal inhibitory concentration: > 100000 nM
Compound 3: only a limit was reported (the forecaster's own chance of this, stated with the estimate: 25%); middle value at least 4.0-fold (0.60 log units) from the limit.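

Compound 3 is reported only as a limit in this assay, > 100000 nM. Piperidin-1-yl in place of ethyl next to the ring nitrogen gives an at least 2.6-fold higher number from compound 2 to compound 3 (0.42 log units; beyond the scatter), so this position does not tolerate every larger group, and this first single-place change in the series runs towards weaker inhibition. The full size of the step cannot be read: the limit of > 100000 nM in this assay, at which 1 of the 3 values shown sits.

Going by these compounds, whether the ring or its nitrogen drives the step stays open. A dimethylamino group or a morpholin-4-yl ring at this position would bear on that question.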